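Trimming the Isopropyl: What an Ethyl Analogue Should Show

The source may report more compounds than this note shows. Statements on the series, on what has been measured and on what is new or still open speak of the compounds shown alone.

For the measured compounds named here, in a functional assay on A549 cells (Homo sapiens) for antiproliferative activity, read by CCK-8 assay, with a stated time of 72 h (a lower number here means a stronger inhibitor, a higher number a weaker inhibitor), compound 1 `Cc1ccc(OCc2ccc(C(=O)Nc3ccccc3N)cc2)cc1` gives 5430 nM and compound 2 `CC(C)c1ccc(OCc2ccc(C(=O)Nc3ccccc3N)cc2)cc1` gives 7460 nM, the larger of the two numbers measured so far, though the move a 1.4-fold higher number from compound 1 to compound 2 (0.14 log units; within the scatter) lies within the scatter. Compound 3 `CCc1ccc(OCc2ccc(C(=O)Nc3ccccc3N)cc2)cc1` differs from compound 2 by hydrogen in place of methyl on a saturated chain carbon bound to an aromatic carbon and a saturated chain carbon. Going by the values given here, the only step that bears on this, a 1.4-fold higher number from compound 1 to compound 2 (0.14 log units; within the scatter), is the same sort of change run the other way and stayed within the scatter, so compound 3 is expected to shift by a 1.2-fold lower number from compound 2 to compound 3 (0.07 log units; within the scatter), nothing beyond the scatter. Compound 3 is therefore estimated at 6300 nM, between 3500 nM and 11000 nM.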

Compound 3, half-maximal inhibitory concentration: 6420 nM
Compound 3: the middle estimate sits 1.0-fold (0.01 log units) below what was measured, and the stated range covers the measured number.
By their numbers in this assay, from the lowest: compounds 1, 3 and 2 (each within the scatter of the next).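

Cutting isopropyl back to ethyl gives a 1.2-fold lower number from compound 2 to compound 3 (0.07 log units; within the scatter) in this assay and adding one methyl to the chain of compound 1 gives a 1.2-fold higher number from compound 1 to compound 3 (0.07 log units; within the scatter) so ethyl fills the gap in the series without separating from either neighbour. At this position, methyl, ethyl and isopropyl therefore cannot be told apart in this assay. Nothing available explains this lack of separation.

Still open, from the compounds shown here alone, is whether a longer chain, an amine or a carboxylic acid at this position would move the number beyond the scatter.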